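Methyl for chloro on the benzoyl aryl: cytotoxicity notes

A few compounds are considered here, and "the series" means these few. Any claim that something is new, unique, unknown or untested is made for them only; others in the source may bear on it.

Measured in an ADME assay on NIH3T3 cells (Mus musculus) for cytotoxicity, read by MTT assay, with a stated time of 48 h; on this read-out lower numbers stand for stronger inhibition and higher numbers for weaker inhibition:
compound 1 `Cc1ccc(C(=O)c2cc(F)c(OCC(=O)NNC(=O)c3ccc(=O)oc3)c(Cl)c2)cc1` gives 28900 nM
compound 2 `Cn1cnc(C(=O)NNC(=O)COc2c(F)cc(C(=O)c3ccc(F)cc3)cc2Cl)c1` gives 89200 nM
compound 3 `Cn1cnc(C(=O)NNC(=O)COc2c(F)cc(C(=O)c3ccc(Cl)cc3)cc2Cl)c1` gives 87800 nM

Compound 3 stands second highest of the three numbers; compound 2 lies within the scatter of it, while compound 1 stands lower, beyond the scatter. Compound 4 `Cc1ccc(C(=O)c2cc(F)c(OCC(=O)NNC(=O)c3cn(C)cn3)c(Cl)c2)cc1` differs from compound 3 by methyl in place of chloro on an aromatic carbon. Going by the values given here, the only measured step at this aromatic carbon, a 1.0-fold lower number from compound 2 to compound 3 (0.01 log units; within the scatter), stayed within the scatter. Compound 1 also carries the methyl on that aromatic carbon but differs elsewhere in the core, so its lower number cannot be read as the effect of the methyl alone. A small step is therefore expected, if anything toward a lower number: a 1.3-fold lower number from compound 3 to compound 4 (0.10 log units; within the scatter). Compound 4 is estimated at 70000 nM, between 35000 nM and 150000 nM.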

Compound 4, half-maximal inhibitory concentration: 94200 nM
The estimate for compound 4 lay 1.3-fold (0.13 log units) below the measured number; the range from low to high includes it.
By their numbers in this assay, from the lowest: compound 1; then compounds 3, 2 and 4 (each within the scatter of the next).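

In this assay, the change from 4-chlorophenyl to 4-methylphenyl gives a 1.1-fold higher number from compound 3 to compound 4 (0.03 log units; within the scatter), and methyl in place of fluoro gives a 1.1-fold higher number from compound 2 to compound 4 (0.02 log units; within the scatter), so fluoro, chloro and methyl on this aromatic carbon cannot be told apart. With the methyl held fixed, changing the ring group on the carbonyl carbon gives a 3.3-fold higher number from compound 1 to compound 4 (0.51 log units; beyond the scatter), which places the lower number of compound 1 with that group rather than with the methyl. Nothing available explains either result.

On these data alone, whether an amine or a carboxylic acid on this aromatic carbon would move the number beyond the scatter remains open. So does whether the ring-group step holds with chloro or fluoro in place of the methyl.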